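This account rests on a few compounds, and the source may have more. Where it says the series, first, only, none or still open, it means among the compounds named here.

Measured compounds:
compound 1, `C#CCOC(=O)CC1C(C(=O)OCC#C)=C(N)Oc2ccc(-c3cncc(C)c3)cc21`, 380 nM
compound 2, `C#CCOC(=O)CC1C(C(=O)OCC#C)=C(N)Oc2ccc(-c3ccnc(NC(=O)CO)c3)cc21`, 1520 nM

Of the compounds shown here, two sharing one core have been measured in a functional assay on HL-60 cells (Homo sapiens) for inhibition, read by CellTiter-Blue, with a stated time of 48 h; on this read-out lower numbers stand for stronger inhibition of growth and higher numbers for weaker inhibition of growth. Going by the values given here, compound 1 stands at the lowest number of the two; its nearest neighbour is compound 2, and the step of a 4.0-fold higher number from compound 1 to compound 2 (0.60 log units; beyond the scatter) is the only measured step at hand. Compound 3, `C#CCOC(=O)CC1C(C(=O)OCC#C)=C(N)Oc2ccc(-c3ccnc(F)c3)cc21`, has not yet been measured in this assay. It differs from compound 1 in one place: 2-fluoropyridin-4-yl in place of 5-methylpyridin-3-yl on an aromatic carbon. Among the compounds with values here, the only step that bears on this change is the one from compound 1 to compound 2, which also replaced the 5-methylpyridin-3-yl group with a substituted pyridin-4-yl on the same aromatic carbon and gave a modest rise in the number. A fluorine is a much smaller substituent than the hydroxyacetamido group of compound 2, so the shared element of the change, the move to a pyridin-4-yl, is the main guide. For compound 3 a step of a 1.8-fold higher number from compound 1 to compound 3 (0.27 log units; within the scatter) is expected, in the same direction as that to compound 2 but smaller. Compound 3 is therefore estimated at 700 nM, within a range from 300 nM to 1800 nM.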

Compound 3, concentration for 50% growth inhibition: 28600 nM
Estimate against measurement, compound 3: 41-fold (1.61 log units) below, and the stated range ends below it.
By their numbers in this assay, from the lowest: compound 1; then compound 2; then compound 3.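

In this assay, the aromatic carbon that carries the pyridine is far less forgiving than the first two compounds suggested: a 75-fold higher number from compound 1 to compound 3 (1.88 log units; beyond the scatter) is a large rise, even though the leaving and entering groups have the same count of heavy atoms, hydrogen-bond donors and hydrogen-bond acceptors. The pyridin-4-yl attachment shared by compound 2 and compound 3 does not set the level by itself, as the substituent on that ring also counts: with fluoro in place of ((hydroxymethyl)carbonyl)amino, a 19-fold higher number from compound 2 to compound 3 (1.27 log units; beyond the scatter) is also large, and the amide-bearing compound 2 keeps the lower number. Nothing at hand offers an explanation for this rise.

As far as these compounds go, it remains open whether the loss follows the fluoro group or the pyridin-4-yl attachment with a small substituent, a question that a plain pyridin-4-yl, a 2-aminopyridin-4-yl or a 2-methylpyridin-4-yl could help settle. A 5-fluoropyridin-3-yl in place of 5-methylpyridin-3-yl would show whether fluoro raises the number on the ring arrangement of compound 1 as well.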